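This account rests on a few compounds, and the source may have more. Where it says the series, first, only, none or still open, it means among the compounds named here.

The measured compounds and their values:

Compound 1, `Cn1c(/C=C2\SC(=O)N(CC(=O)Nc3nc(-c4ccccc4)cs3)C2=O)nc2ccccc21`, in a functional assay on PC-3 cells (Homo sapiens) for inhibition, read by MTT assay, with a stated time of 48 h (on this read-out higher numbers stand for weaker inhibition and lower numbers for stronger inhibition), gives 39900 nM.
Compound 2, `CCn1c(/C=C2\SC(=O)N(CC(=O)N3CCCC3)C2=O)nc2ccccc21`, gives in this assay only a limit, > 50000 nM.
Compound 3, `Cn1c(/C=C2\SC(=O)N(CC(=O)N3CCCC3)C2=O)nc2ccccc21`, likewise gives only a limit in this assay, > 50000 nM.

For the measured compounds named here, compound 1 carries the only number of the three; the other two values sit at the limit of > 50000 nM in this assay, at which 2 of the 3 values shown sit, which is a limit of the assay and not a number. Compound 3 and compound 2 differ in one place, (methyl in place of hydrogen on a saturated chain carbon bound to an aromatic nitrogen). Since both of them sit at the limit, the step that the two limits leave unreadable from compound 3 to compound 2 cannot be read in size or direction.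

Compound 4, `CCn1c(/C=C2\SC(=O)N(CC(=O)Nc3nc(-c4ccccc4)cs3)C2=O)nc2ccccc21`, has not been measured. It differs from compound 1 by methyl in place of hydrogen on a saturated chain carbon bound to an aromatic nitrogen, the same change that leads from compound 3 to compound 2, made here on a different core; the difference between the core of compound 1 and the core of compound 3 is not broken down here.

Going by the values given here, what to expect from compound 1 to compound 4 rests only on the fact that compound 1 gives a number, 39900 nM, while the one measured example of this change stays unreadable, and that a single methyl entering is a small change. The step from compound 1 to compound 4 is therefore expected to be small, a 1.1-fold higher number from compound 1 to compound 4 (0.05 log units; within the scatter). For compound 4 in this assay the estimate is 45000 nM, expected to lie between 18000 nM and 110000 nM, with a real chance that only a limit is reported.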

Compound 4, half-maximal inhibitory concentration: > 50000 nM
Compound 4: a limit, no number (the forecaster's own chance of this, stated with the estimate: 40%); at least 1.1-fold (0.04 log units) between middle value and limit.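

In this assay the change from 1-methyl-1H-benzimidazol-2-yl to 1-ethyl-1H-benzimidazol-2-yl gives an at least 1.2-fold higher number from compound 1 to compound 4 (0.09 log units; that floor lies within the scatter) on the core of compound 1. Compound 4 gives > 50000 nM as its value, which is a limit of the assay and not a number, so this step is only a floor, and it shows no more than that the change does not bring a lower number on this core, not that it truly weakens inhibition. Whether the change acts alike on the two cores cannot be judged, since the matching step from compound 3 to compound 2 cannot be read in size or direction, and very few real numbers exist here to compare: the limit of > 50000 nM in this assay, at which 3 of the 4 values shown sit.

The compounds shown leave open how the series responds when something other than methyl or ethyl sits at this place, for example a propyl chain or a longer chain ending in an amine or a carboxylic acid. For the compounds shown here, they also leave open whether any such group would bring a number clearly lower than the one compound 1 gives, and whether the same group would act alike on both cores.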